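This account rests on a few compounds, and the source may have more. Where it says the series, first, only, none or still open, it means among the compounds named here.

Measured so far:
- compound 1, `CC(C)[C@H](C(=O)NO)N(CCN=[N+]=[N-])S(=O)(=O)c1ccc(OCCF)cc1`: 4 nM
- compound 2, `Cc1ccc(S(=O)(=O)N(CCn2cc(CCCF)nn2)[C@@H](C(=O)NO)C(C)C)cc1`: 3 nM
- compound 3, `CC(C)[C@H](C(=O)NO)N(CCn1cc(CCCF)nn1)S(=O)(=O)c1ccc(OCCF)cc1`: 2 nM

All three were tested in an assay on isolated protein for inhibition of matrix metalloproteinase-9 (Homo sapiens), read by fluorescence, with a stated time of 30 min; on this read-out lower numbers stand for stronger inhibition and higher numbers for weaker inhibition. Compound 3 sits close to its two neighbours: the step of a 2.0-fold lower number from compound 1 to compound 3 (0.30 log units; within the scatter) and the step of a 1.5-fold lower number from compound 2 to compound 3 (0.18 log units; within the scatter) both stay within the scatter, so the three numbers cannot be told apart with confidence.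

Compound 4, `CC(C)[C@H](C(=O)NO)N(CCn1cc(CNS(=O)(=O)c2ccc(F)cc2)nn1)S(=O)(=O)c1ccc(OCCF)cc1`, is not yet measured. It differs from compound 3 by one change: ((4-fluorophenyl)sulfonyl)amino in place of 2-fluoroethyl on a saturated chain carbon bound to an aromatic carbon. For the measured compounds named here, the only measured step touching the same region of the molecule is the one from compound 1 to compound 3, where a much larger group replaced a small one on the chain two bonds from the sulfonamide nitrogen and the number barely moved, a 2.0-fold lower number from compound 1 to compound 3 (0.30 log units; within the scatter). The step from compound 2 to compound 3 concerns a different part of the molecule and says nothing about this change. On that basis no movement beyond the scatter is expected for compound 4 in this assay, with the estimated step being a 1.5-fold higher number from compound 3 to compound 4 (0.18 log units; within the scatter). Compound 4 is therefore expected to give about 3 nM, in a range from 1 nM to 10 nM.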

Compound 4, half-maximal inhibitory concentration: 3 nM
For compound 4 middle estimate and measured number coincide at the digits printed; low and high end bracket the measured number.
By their numbers in this assay, from the lowest: compounds 3, 2, 4 and 1 (each within the scatter of the next).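

In this assay, putting ((4-fluorophenyl)sulfonyl)amino in place of 2-fluoroethyl on a saturated chain carbon bound to an aromatic carbon gives a 1.5-fold higher number from compound 3 to compound 4 (0.18 log units; within the scatter), so the two compounds cannot be told apart. For the compounds shown here, compounds 2 and 3 both carry 3-fluoropropyl here, so this is the first view of a different group at this place, and a group of 11 heavy atoms with a six-membered aromatic ring, a hydrogen-bond donor and hydrogen-bond acceptors leaves the number within the scatter. No measurement shown bears on the reason for this result.

On these data alone, whether a simple amine or a carboxylic acid at this place would also keep the number within the scatter remains open. So does whether the same change would give a similar step on compound 2, with methyl in place of 2-fluoroethoxy.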